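Thiazolyl acetic acids: aryl swap from compound 3 to compound 4

The source may report more compounds than this note shows. Statements on the series, on what has been measured and on what is new or still open speak of the compounds shown alone.

Measured so far in an in vitro assay on HEK385-7 cells for displacement of a labelled ligand from prostaglandin D2 receptor 2 (Homo sapiens); on this read-out lower numbers stand for stronger inhibition and higher numbers for weaker inhibition:
compound 1 `O=C(O)Cc1sc(NC(=O)c2ccccc2)nc1-c1ccc(Cl)cc1`: 520 nM
compound 2 `O=C(O)Cc1sc(CSc2ccccc2)nc1-c1ccc(Cl)cc1`: 250 nM
compound 3 `N#Cc1cc(-c2nc(C(c3ccc(F)cc3)c3ccc(F)cc3)sc2CC(=O)O)ccc1F`: 57 nM

Compound 3 stands lowest of the three numbers; compound 2 is the nearest to it and compound 1 the furthest, and both gaps are beyond the usual scatter. Compound 3 is therefore the strongest inhibitor among the measured compounds.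

Compound 4 `O=C(O)Cc1sc(C(c2ccc(F)cc2)c2ccc(F)cc2)nc1-c1ccnc(N2CCC2)c1` is not yet measured. It differs from compound 3 in one place: 2-(azetidin-1-yl)pyridin-4-yl in place of 3-cyano-4-fluorophenyl on an aromatic carbon. Within the data shown here, no measured pair shows this change, so its effect can only be judged from the single anchor given by compound 3 in this assay.

The step of a 1.4-fold higher number from compound 3 to compound 4 (0.15 log units; within the scatter) is expected to stay within the scatter, or at most to run slightly towards weaker inhibition. In this assay compound 4 is accordingly estimated at 80 nM, with a range from 25 nM to 250 nM.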

Compound 4, half-maximal inhibitory concentration: 660 nM
Compound 4: middle estimate off by 8.3-fold (0.92 log units), on the low side; the measured number lies above the stated range.
By their numbers in this assay, from the lowest: compound 3; then compound 2; then compounds 1 and 4 (each within the scatter of the next).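

In this assay, among these compounds, the step of a 12-fold higher number from compound 3 to compound 4 (1.06 log units; beyond the scatter) is large and gives the first direct reading at this position, the aromatic carbon next to the ring nitrogen, with the rest of the molecule unchanged. The position is therefore not indifferent to the group it carries, and 2-(azetidin-1-yl)pyridin-4-yl is a poor replacement for 3-cyano-4-fluorophenyl on this core. The swap changes several things at once, removing the nitrile and the fluorine and bringing in a ring nitrogen and a four-membered ring, and nothing at hand assigns the step to any one of these.

Still open, on these data alone, is whether the aromatic pyridine ring or the azetidine carries the step, which a plain pyridin-4-yl or a dimethylamino group in place of azetidine would help to separate. Equally open, as far as these compounds go, is how much of the value of compound 3 depends on the nitrile or on the fluorine alone.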